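The source may hold more compounds than are shown below. What is called first, only, known or untested is meant among the compounds shown, and "the series" means these compounds.

This account concerns a small set of compounds that share one core and are compared in a functional assay on the whole organism with Mus musculus as the target; a lower number here means a smaller maximal response, a higher number a larger maximal response. For the measured compounds named here, compound 1, `C=CCn1c(=O)n([C@H]2CO[C@@H](CO)C2)c2nc(N)nc(O)c21`, gives 16% in this assay, the lowest of the three numbers known. Compound 2, `CN(C)CCCn1c(=O)n(C2OC(CO)[C@@H](O)[C@H]2O)c2nc(N)nc(O)c21`, gives 63%, and compound 3, `CCn1c(=O)n(C2OC(CO)[C@@H](O)[C@H]2O)c2nc(N)nc(O)c21`, gives 82%. Going by the values given here, the only step between measured compounds that differ in a single place, a number 19 percentage points higher from compound 2 to compound 3 (beyond the scatter), concerns the chain on the aromatic nitrogen, not the ring that is changed here. Among the compounds with values here, compound 4, `C=CCn1c(=O)n(C2C=CC(CO)O2)c2nc(N)nc(O)c21`, differs from compound 1 at another place: a group of 7 heavy atoms (5 carbon, 2 oxygen; one five-membered non-aromatic ring with 1 hetero atom) in place of a group of 7 heavy atoms (5 carbon, 2 oxygen; one five-membered non-aromatic ring with 1 hetero atom), on an aromatic nitrogen No measured step covers such an exchange of one five-membered non-aromatic ring for another, so the known numbers give no direct guide to the size or direction of the change. Compound 4 is therefore expected to show a step of only a number 4 percentage points higher from compound 1 to compound 4 (within the scatter) in this assay. The estimate for compound 4 in this assay is 20%, with a range from 5% to 45%.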

Compound 4, largest response reached (reported as maximal response), in percent of the reference or control that the assay uses: 84%
For compound 4 the middle estimate is 64 percentage points below the measured one; measured number above the stated range.
By their numbers in this assay, from the lowest: compound 1; then compound 2; then compounds 3 and 4 (each within the scatter of the next).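

In this assay the exchange on the aromatic nitrogen gives a number 68 percentage points higher from compound 1 to compound 4 (beyond the scatter), with the allyl group unchanged. This shows that the position responds strongly to the identity of the five-membered non-aromatic ring, even though the leaving and entering groups match in heavy atoms, hydrogen-bond donors, hydrogen-bond acceptors and net charge. The counted differences are the double bond outside aromatic rings, which only the entering group has, and the defined stereocentres, which are counted only in the leaving group.

Nothing shown here gives a reason for the step. The compounds shown leave open whether the double bond or the stereocentres account for the change, and how a ring carrying an amine or a carboxylic acid would behave on this aromatic nitrogen.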